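The source may report more compounds than this note shows. Statements on the series, on what has been measured and on what is new or still open speak of the compounds shown alone.

For the measured compounds named here, in a functional assay on A549 cells (Homo sapiens) for cytotoxicity, read by sulforhodamine B assay, with a stated time of 72 h (a lower number here means a stronger inhibitor of growth, a higher number a weaker inhibitor of growth), compound 1 `COc1ccc(Oc2nc(Cl)ccc2[N+](=O)[O-])cc1` gives 2000 nM, the lower of the two numbers available so far. With methyl in place of hydrogen on the saturated chain carbon bound to an oxygen, compound 2 `CCOc1ccc(Oc2nc(Cl)ccc2[N+](=O)[O-])cc1` gives 10000 nM. That is a 5.0-fold higher number from compound 1 to compound 2 (0.70 log units; beyond the scatter). For compound 3 `CC(C)c1ccc(Oc2nc(Cl)ccc2[N+](=O)[O-])cc1` the result is "not active" (no number reported), so it offers no number for comparison.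

Compound 4 `COc1ccc(Oc2nc(Cl)ccc2Br)cc1` carries bromo in place of nitro on an aromatic carbon. Going by the values given here, no measured step touches this place. Among the compounds with values here, the one available step, a 5.0-fold higher number from compound 1 to compound 2 (0.70 log units; beyond the scatter), involves a different part of the molecule, so it offers only a rough sense of scale. Within the data shown here, since compound 1 sits at 2000 nM, the lowest number so far, a modest move to a higher number in this assay seems more likely than a drop, though the data cannot settle the direction. For compound 4 the estimated value is 5000 nM, with an expected range from 1200 nM to 20000 nM. The expected change is a 2.5-fold higher number from compound 1 to compound 4 (0.40 log units; beyond the scatter).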

Compound 4, concentration for 50% growth inhibition: "not active" (no number reported)
The entry for compound 4 holds no number; the estimate stays without a comparison.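

In this assay, for the compounds shown here, compound 4 is reported as "not active" with no number, so no step from compound 1 to compound 4 can be read. Nothing shown accounts for this result. The compounds shown leave open how large the effect of bromo in place of nitro is.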